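The source may hold more compounds than are shown below. What is called first, only, known or untested is meant among the compounds shown, and "the series" means these compounds.

Of the compounds shown here, two of a shared core have been measured in a functional assay on CHO cells for antagonist activity at transient receptor potential cation channel subfamily V member 1 (Homo sapiens), read by FLIPR; a lower number here means a stronger inhibitor, a higher number a weaker inhibitor. Compound 1, `FC(F)(F)c1ccc(-c2nc3cc(-c4ncccc4C(F)(F)F)ccc3[nH]2)cc1`, gives 22 nM. Compound 2, `Cc1ccc(-c2nc3cc(-c4ncccc4C(F)(F)F)ccc3[nH]2)cc1`, gives 170 nM in this assay. Going by the values given here, the one step between them, a 7.7-fold higher number from compound 1 to compound 2 (0.89 log units; beyond the scatter), is the only comparison available, and on these two numbers compound 2 stands with the higher of the two.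

Compound 3 is `Fc1ccc(-c2nc3cc(-c4ncccc4C(F)(F)F)ccc3[nH]2)cc1`. It differs from compound 2 in one place: fluoro in place of methyl on an aromatic carbon. Among the compounds with values here, the only step that bears on this change is the exchange of trifluoromethyl for methyl at the same place, a 7.7-fold higher number from compound 1 to compound 2 (0.89 log units; beyond the scatter), which shows that the group at this position matters in this assay. Fluoro is neither of those two groups, so the expected size is uncertain; a move back toward compound 1 is expected, as a 1.5-fold lower number from compound 2 to compound 3 (0.19 log units; within the scatter), which may not exceed the scatter. The estimate for compound 3 in this assay is 110 nM, with a range from 45 nM to 280 nM.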

Compound 3, half-maximal inhibitory concentration: 320 nM
Estimate against measurement, compound 3: 2.9-fold (0.46 log units) below; measured number outside the range, above it.
By their numbers in this assay, from the lowest: compound 1; then compounds 2 and 3 (each within the scatter of the next).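

With fluoro on this aromatic carbon, the result in this assay is a 1.9-fold higher number from compound 2 to compound 3 (0.27 log units; within the scatter), so methyl and fluoro are not separated at this position. Trifluoromethyl now stands apart from both groups, with a 15-fold higher number from compound 1 to compound 3 (1.16 log units; beyond the scatter) alongside a 7.7-fold higher number from compound 1 to compound 2 (0.89 log units; beyond the scatter), which makes compound 1 the strongest inhibitor of the three. Nothing available here accounts for what sets trifluoromethyl apart from the other two groups.

The compounds shown leave open whether that gap belongs to trifluoromethyl alone or would also appear with a chlorine atom, a nitrile or a methoxy group at this place, para to a large group. They also leave open how a bulkier carbon group such as tert-butyl would compare with trifluoromethyl there.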